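The source may report more compounds than this note shows. Statements on the series, on what has been measured and on what is new or still open speak of the compounds shown alone.

Compound 2, `O=C(/C=C/c1ncc2ccccc2n1)Nc1ccc2ncnc(Nc3cccc(Cl)c3)c2c1`, and compound 1, `Clc1cccc(Nc2ncnc3ccc(NCc4cccc(Br)n4)cc23)c1`, share a core that has been tested in a functional assay on A549 cells (Homo sapiens) for antiproliferative activity, read by MTT assay, with a stated time of 48 h; on this read-out lower numbers stand for stronger inhibition and higher numbers for weaker inhibition. In this assay compound 1 gives 2950 nM. In this assay compound 2 gives 3350 nM. Among the measured compounds shown here, of the two numbers the one of compound 2 is the higher, but the gap to compound 1 lies within the scatter, so the two cannot be told apart on this read-out.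

Compound 3, `O=C(/C=C/c1cccs1)Nc1ccc2ncnc(Nc3cccc(Cl)c3)c2c1`, has not yet been measured in this assay. It differs from compound 2 in one place: thiophen-2-yl in place of quinazolin-2-yl on a double-bonded chain carbon bound to a double-bonded chain carbon. For the measured compounds named here, no step of this kind between measured compounds is available, so there is nothing from which its size can be read off. Going by these compounds, the expectation for compound 3 is a step of a 1.5-fold higher number from compound 2 to compound 3 (0.17 log units; within the scatter), with a wide range, since the effect of this exchange is untested here. Compound 3 is therefore estimated to give 5000 nM in this assay, between 1500 nM and 16000 nM.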

Compound 3, half-maximal inhibitory concentration: 9310 nM
For compound 3 the middle estimate is 1.9-fold (0.27 log units) below the measured one; the measured number falls inside the stated range.
By their numbers in this assay, from the lowest: compounds 1 and 2 (each within the scatter of the next); then compound 3.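

In this assay, putting thiophen-2-yl in place of quinazolin-2-yl on a double-bonded chain carbon bound to a double-bonded chain carbon gives a 2.8-fold higher number from compound 2 to compound 3 (0.44 log units; beyond the scatter) and so shows that the group held at this place can change the result beyond the scatter. The exchange of (6-bromopyridin-2-yl)methyl for (2-(thiophen-2-yl)ethenyl)carbonyl on a nitrogen on an aromatic ring gives a 3.2-fold higher number from compound 1 to compound 3 (0.50 log units; beyond the scatter) and leaves compound 3 as the weakest of the three, even though compound 1 and compound 2 cannot be told apart. Nothing measured here explains why the number rises with either change.

With only two groups shown at this place on the chain, it remains open whether the number follows the size of the group or the kind of ring it contains. A phenyl group or a pyridin-2-yl group at this place, or a longer chain ending in a dimethylamino group, would test this further.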